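A few compounds are considered here, and "the series" means these few. Any claim that something is new, unique, unknown or untested is made for them only; others in the source may bear on it.

Compound 1 `CCOC(=O)c1nnn(-c2cccc(NC(=O)c3ccc(/C=C/C(=O)c4ccc(Cl)cc4)cc3)c2)c1C` gives "not determined" (no result reported) in an ADME assay on Vero cells (Chlorocebus sabaeus) for cytotoxicity, read by MTT assay, with a stated time of 72 h; a lower number here means that less compound is tolerated, a higher number that more compound is tolerated.
Compound 2 `COC(=O)c1cc(-c2cccc(NC(=O)c3ccc(/C=C/C(=O)c4ccc(Br)cc4)cc3)c2)on1` gives > 20 ug/mL in this assay, which is a limit of the assay rather than a number.
Compound 3 `COC(=O)c1cc(-c2cccc(NC(=O)c3ccc(/C=C/C(=O)c4cccc(Cl)c4)cc3)c2)on1` gives > 2.5 ug/mL in this assay, again a limit rather than a number.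

Among the compounds with values here, compound 3 therefore stands only at a limit, and the single step that reaches it, a step that the two limits leave unreadable from compound 2 to compound 3, cannot be read in size because both ends are limits (the limit of > 20 ug/mL in this assay, at which 1 of the 3 values shown sits, and (the limit of > 2.5 ug/mL in this assay, at which 1 of the 3 values shown sits)). Compound 4 `COC(=O)c1cc(-c2cccc(NC(=O)c3ccc(/C=C/C(=O)c4ccc(Cl)cc4)cc3)c2)on1` differs from compound 3 by 4-chlorophenyl in place of 3-chlorophenyl on a carbonyl carbon. Within the data shown here, no measured step bears on this change, so no direction can be drawn; the expectation is simply that compound 4 will also be tolerated up to a limit, with a step that the limit leaves unreadable from compound 3 to compound 4 expected to stay within the scatter. Compound 4 is estimated at 30 ug/mL, ranging from 5 ug/mL to 100 ug/mL.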

Compound 4, half-maximal cytotoxic concentration: > 50 ug/mL
Compound 4 was reported as a limit; the forecaster's own chance of this, stated with the estimate: 70%; middle value at least 1.6-fold (0.22 log units) away from the limit.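

Within the data shown here, compound 2, compound 3 and compound 4 are all reported as limits in this assay, so no step among them can be read. As far as these compounds go, whether 4-bromophenyl, 3-chlorophenyl or 4-chlorophenyl changes the tolerated concentration at all stays open.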